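Replacing isobutyl with benzyl on compound 3

This account rests on a few compounds, and the source may have more. Where it says the series, first, only, none or still open, it means among the compounds named here.

compound 1 `CC(C)CN(CC(=O)N(CC(C)C)NC(=O)OCc1ccccc1)NC(=O)CBr` gives 3300 nM
compound 2 `CC(C)CN(CC(=O)N(CC(C)C)NC(=O)OCc1ccccc1)NC(=O)CNNC(=O)CBr` gives 2300 nM
compound 3 `CC(C)CN(CC(=O)N(CC(C)C)NC(=O)OCc1ccccc1)/N=C/c1ccccc1B(O)O` gives 17300 nM

In a functional assay on B16 cells (Mus musculus) for inhibition (on this read-out lower numbers stand for stronger inhibition and higher numbers for weaker inhibition), compound 3 stands highest of the three numbers, at 17300 nM. Compound 4 `CC(C)CN(CC(=O)N(Cc1ccccc1)NC(=O)OCc1ccccc1)/N=C/c1ccccc1B(O)O` differs from it by phenyl in place of isopropyl on a saturated chain carbon bound to an amide-type nitrogen. The same difference reads isobutyl to benzyl. For the measured compounds named here, no measured step touches this place. The steps of a 5.2-fold higher number from compound 1 to compound 3 (0.72 log units; beyond the scatter) and a 7.5-fold higher number from compound 2 to compound 3 (0.88 log units; beyond the scatter) were modest, but both concern the group on an amine nitrogen, and a 1.4-fold lower number from compound 1 to compound 2 (0.16 log units; within the scatter) concerns that same end. They give no direction for the new change, so no step beyond the scatter is expected, though with wide uncertainty. The expected step is a 1.2-fold lower number from compound 3 to compound 4 (0.06 log units; within the scatter). Compound 4 is estimated at 15000 nM, in a range from 5000 nM to 40000 nM.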

Compound 4, half-maximal inhibitory concentration: 25100 nM
Compound 4: the middle estimate sits 1.7-fold (0.22 log units) below what was measured; low and high end bracket the measured number.
By their numbers in this assay, from the lowest: compounds 2 and 1 (each within the scatter of the next); then compounds 3 and 4 (each within the scatter of the next).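

In this assay, isobutyl to benzyl on a saturated chain carbon bound to an amide-type nitrogen gives a 1.5-fold higher number from compound 3 to compound 4 (0.16 log units; within the scatter). For the compounds shown here, this is the first reading at this place, and it shows that the added ring leaves compound 4 within the scatter of compound 3. Nothing at hand says why the two compounds read alike.

The compounds shown leave open whether a longer chain such as phenethyl, or an amine or a carboxylic acid on the benzyl ring, would read the same here. They also leave open whether benzyl would read alike on compound 1 or compound 2.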